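Truncation of compound 2 to the free aniline

The source may hold more compounds than are shown below. What is called first, only, known or untested is meant among the compounds shown, and "the series" means these compounds.

Compound 2 `COc1cccc(/C=C/C(=O)Nc2cc(C(=O)c3cc(OC)c(OC)c(OC)c3)cc(OC)c2OC)c1` gives 12500 nM in a functional assay on DU-145 cells (Homo sapiens) for cytotoxicity, read by MTT assay, with a stated time of 72 h (a higher number here means a weaker inhibitor, a lower number a stronger inhibitor), the highest of the two numbers shown; compound 1 `COc1ccc(/C=C/C(=O)Nc2cc(C(=O)c3cc(OC)c(OC)c(OC)c3)cc(OC)c2OC)cc1` gives 10400 nM, and the step of a 1.2-fold higher number from compound 1 to compound 2 (0.08 log units; within the scatter) lies within the scatter. Compound 3 `COc1cc(C(=O)c2cc(OC)c(OC)c(OC)c2)cc(N)c1OC` differs from compound 2 by hydrogen in place of (2-(3-methoxyphenyl)ethenyl)carbonyl on a nitrogen on an aromatic ring. No measured step removes this group; the only step shown varies within it and is within the scatter, so no direction beyond the scatter can be inferred. Compound 3 is therefore estimated at 3000 nM with a wide range from 150 nM to 40000 nM, an expected step of a 4.2-fold lower number from compound 2 to compound 3 (0.62 log units; beyond the scatter).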

Compound 3, half-maximal inhibitory concentration: 10000 nM
Compound 3: middle estimate off by 3.3-fold (0.52 log units), on the low side; measured number inside the range.
By their numbers in this assay, from the lowest: compounds 3, 1 and 2 (each within the scatter of the next).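

Hydrogen in place of (2-(3-methoxyphenyl)ethenyl)carbonyl on the nitrogen gives a 1.3-fold lower number from compound 2 to compound 3 (0.10 log units; within the scatter), and hydrogen in place of (2-(4-methoxyphenyl)ethenyl)carbonyl gives a 1.0-fold lower number from compound 1 to compound 3 (0.02 log units; within the scatter). In this assay the whole acyl group, not only the methoxy placement within it, therefore leaves the number within the scatter, so compounds 1, 2 and 3 are not separated at this nitrogen. No evidence at hand bears on this result.

Open, on these data alone, is whether an acetyl group, a sulfonamide or a urea on this nitrogen would stand beyond the scatter from compound 3.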